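Swapping the aryl group on the piperazine of compound 3

The source may report more compounds than this note shows. Statements on the series, on what has been measured and on what is new or still open speak of the compounds shown alone.

Three close relatives share one core and differ only in the aromatic group attached to a ring nitrogen. Compound 1 `CCCc1nc(-c2ccccc2)c(CNCCN2CCN(c3cccc(C(F)(F)F)c3)CC2)o1` gives 56.3% in an assay on HEK293 cells for inhibition of Voltage-dependent T-type calcium channel subunit alpha-1G (Homo sapiens), read by fluorescence, tested at 10 uM; a lower number here means less inhibition, a higher number more inhibition at the concentration tested (going by the name of the read-out); compound 2 `CCCc1nc(-c2ccccc2)c(CNCCN2CCN(c3ccccc3OC)CC2)o1` gives 39.7%; compound 3 `CCCc1nc(-c2ccccc2)c(CNCCN2CCN(c3cccc(F)c3)CC2)o1` gives 62.3%. Compound 3 thus shows the highest of the three numbers, although compound 1 sits within the scatter of it, and only compound 2 lies clearly lower.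

Compound 4 `CCCc1nc(-c2ccccc2)c(CNCCN2CCN(c3ccccc3C)CC2)o1` has not been measured. Its change from compound 3 is 2-methylphenyl in place of 3-fluorophenyl on an amine nitrogen in a ring. Among the compounds with values here, two measured steps bear on this: a number 16.6 percentage points lower from compound 1 to compound 2 (beyond the scatter), and a number 22.6 percentage points higher from compound 2 to compound 3 (beyond the scatter). Both suggest that a 2-substituted phenyl on this ring nitrogen gives a lower number than a 3-substituted one. A modest decrease for compound 4 is therefore expected, beyond the scatter, as a number 18.3 percentage points lower from compound 3 to compound 4 (beyond the scatter). Compound 4 is estimated at 44%, in the range from 30% to 58%.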

Compound 4, a percentage reported as inhibition, at one concentration (the size of the read-out at that concentration, not a potency): 51.3%
The estimate for compound 4 lay 7.3 percentage points below the measured number; the range from low to high includes it.
By their numbers in this assay, from the lowest: compound 2; then compounds 4, 1 and 3 (each within the scatter of the next, the first and the last beyond it).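

Compound 4 shows that a 2-substituted phenyl does not by itself bring the number down to the level of compound 2: replacing methoxy with methyl on that ring gives a number 11.6 percentage points higher from compound 2 to compound 4 (beyond the scatter), while the step from a 3-(trifluoromethyl)phenyl is a number 5 percentage points lower from compound 1 to compound 4 (within the scatter). Compound 4 still differs clearly from the 3-fluorophenyl compound in this assay, with a number 11 percentage points lower from compound 3 to compound 4 (beyond the scatter), so the 3-substituted compounds do not form a single level above the 2-substituted ones. No supporting data explain these differences.

Methyl appears here only in the 2-methylphenyl and fluoro only in the 3-fluorophenyl, so the effects of the group and its position on the ring cannot be separated. Going by these compounds, it also remains open how a phenyl carrying an amine or a carboxylic acid would behave on this ring nitrogen.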